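The source may hold more compounds than are shown below. What is called first, only, known or untested is meant among the compounds shown, and "the series" means these compounds.

Measured compounds in a functional assay on HepG2 cells (Homo sapiens) for cytotoxicity, read by MTT assay, with a stated time of 72 h; on this read-out higher numbers stand for weaker inhibition and lower numbers for stronger inhibition:
- Compound 1 `COc1c(OCCCCN2CCN(C)CC2)cc(O)c2c(=O)cc(-c3ccc(C)cc3)oc12` gives 1000 nM
- Compound 2 `CN(C)CCCOc1c(OCc2ccccc2)cc(O)c2c(=O)cc(-c3ccccc3)oc12` gives 4950 nM

Compound 2 stands at the higher of the two numbers in this assay; compound 1 sits at a markedly lower value, and the gap between the two is beyond the usual scatter. Compounds 1 and 2 differ in more than one place, so nothing is attached to that gap beyond what the two values show.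

Compound 3 `CN(C)CCCCOc1c(OCc2ccccc2)cc(O)c2c(=O)cc(-c3ccccc3)oc12` is the next member. Relative to compound 2 the change is (dimethylamino)methyl in place of dimethylamino on a saturated chain carbon, three bonds along the chain from an oxygen on an aromatic ring; the rest of the molecule is unchanged. Within the data shown here, no step of this kind has been measured, so there is no measured reference for the size of such a change. On the present data the step from compound 2 to compound 3 is expected to be small, with no clear direction beyond the scatter, and the estimate leans only slightly toward a lower number, a 1.4-fold lower number from compound 2 to compound 3 (0.15 log units; within the scatter). For compound 3 in this assay the expected value is 3500 nM, with a range from 1200 nM to 10000 nM.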

Compound 3, half-maximal inhibitory concentration: 2090 nM
For compound 3 the middle estimate is 1.7-fold (0.22 log units) above the measured one, within the range that was stated.
By their numbers in this assay, from the lowest: compound 1; then compound 3; then compound 2.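

In this assay, the lengthening of the chain end, with (dimethylamino)methyl in place of dimethylamino on a saturated chain carbon, three bonds along the chain from an oxygen on an aromatic ring, gives a 2.4-fold lower number from compound 2 to compound 3 (0.37 log units; beyond the scatter) and nothing else in the molecule changes. Among these compounds, this is the first single-place step, and it shows that this position is not silent: the 4-(dimethylamino)butyl chain of compound 3 reads differently from the 3-(dimethylamino)propyl chain of compound 2, modestly but beyond the scatter. Nothing at hand bears on what lies behind this step.

One step gives a size and direction for this single pair, not a trend with chain length. Open, going by these compounds, are whether a shorter 2-(dimethylamino)ethyl chain or a longer 5-(dimethylamino)pentyl chain on the same oxygen would fall in line with this step, and whether a morpholine or pyrrolidine at the chain end would read like dimethylamino.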